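The source may hold more compounds than are shown below. What is called first, only, known or untested is meant among the compounds shown, and "the series" means these compounds.

Of the compounds shown here, two built on the same core have so far been tested in a functional assay on A549 cells (Homo sapiens) for cytotoxicity, read by sulforhodamine B assay, with a stated time of 48 h; on this read-out lower numbers stand for stronger inhibition and higher numbers for weaker inhibition. Compound 1 `COc1ccc(/C=C2\C(=O)N(Cc3cn([C@@H]4O[C@H](COC(C)=O)[C@@H](OC(C)=O)[C@H](OC(C)=O)[C@H]4OC(C)=O)nn3)c3ccccc32)cc1OC` gives 23300 nM in this assay. Compound 2 `CC(=O)OC[C@H]1O[C@@H](n2cc(CN3C(=O)/C(=C/c4cccs4)c4ccccc43)nn2)[C@H](OC(C)=O)[C@@H](OC(C)=O)[C@@H]1OC(C)=O` gives 20800 nM in this assay. These two numbers lie within the scatter of each other, so neither compound can be set apart from the other on this read-out. Compound 3 `CC(=O)OC[C@H]1O[C@@H](n2cc(CN3C(=O)/C(=C\c4cccs4)c4ccccc43)nn2)[C@H](OC(C)=O)[C@@H](OC(C)=O)[C@@H]1OC(C)=O` has not yet been measured. Compound 3 differs from compound 2 in a single point: the two compounds have the same atoms and bonds and differ only in configuration as drawn: 1 of 6 stereo elements differ; a double bond is drawn E in compound 2 and Z in compound 3. Among the compounds with values here, no pair of measured compounds isolates a change of exactly this kind, so there is no measured step to lean on. Under that gap, the step expected in this assay is a 1.1-fold higher number from compound 2 to compound 3 (0.02 log units; within the scatter), with no clear direction and not beyond the usual scatter. For compound 3 in this assay the estimate is 22000 nM, inside a range from 9000 nM to 55000 nM.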

Compound 3, half-maximal inhibitory concentration: 16100 nM
Beside the measured number, compound 3's estimate is 1.4-fold (0.14 log units) above it; the measured number falls inside the stated range.
By their numbers in this assay, from the lowest: compounds 3, 2 and 1 (each within the scatter of the next).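

Turning the double bond around gives a 1.3-fold lower number from compound 2 to compound 3 (0.11 log units; within the scatter), so in this assay the geometry at this double bond does not set the two compounds apart. This pair tests that double bond alone, with no group entering or leaving: the fact that compounds 2 and 3 differ only in the configuration as drawn. The swap of 3,4-dimethoxyphenyl for thiophen-2-yl gives a 1.4-fold lower number from compound 1 to compound 3 (0.16 log units; within the scatter), so this change on the double-bonded chain carbon also stays within the scatter, and all three compounds remain indistinguishable on this read-out.

Going by these compounds, both groups at this position are rings, so it remains open whether an amine or a carboxylic acid there would move the number beyond the scatter. The compounds shown also leave open whether the double-bond geometry would matter in a compound with a lower number.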